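Substituting the Amidine Phenyl Ring of Compound 1

The source may hold more compounds than are shown below. What is called first, only, known or untested is meant among the compounds shown, and "the series" means these compounds.

Measured compounds:
compound 1 `N=C(Nc1ccccc1)c1cc2c(-c3ccccc3)n[nH]c2c(NC2CCCCC2)n1` gives 850 nM
compound 2 `COc1cc(Nc2nc(C(=N)Nc3ccccc3)cc3c(-c4ccccc4)n[nH]c23)cc(OC)c1OC` gives 3900 nM
compound 3 `N=C(Nc1cccc(C(F)(F)F)c1)c1cc2c(-c3ccccc3)n[nH]c2c(NC2CCCCC2)n1` gives 21200 nM

These three compounds share one core and were compared in a functional assay on HT-1080 cells (Homo sapiens) for cytotoxicity, read by MTT assay, with a stated time of 72 h; on this read-out higher numbers stand for weaker inhibition and lower numbers for stronger inhibition. Compound 1 stands lowest of the three numbers; its nearest neighbour is compound 2, reached by the step of a 4.6-fold higher number from compound 1 to compound 2 (0.66 log units; beyond the scatter), and the furthest is compound 3, reached by the step of a 25-fold higher number from compound 1 to compound 3 (1.40 log units; beyond the scatter). Both changes away from compound 1 therefore gave higher numbers, one modest and one large.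

Compound 4 `CN1CCN(c2ccc(NC(=N)c3cc4c(-c5ccccc5)n[nH]c4c(NC4CCCCC4)n3)cc2)CC1` has not yet been measured. It differs from compound 1 in one place: 4-methylpiperazin-1-yl in place of hydrogen on an aromatic carbon. The step that bears most directly on this change is a 25-fold higher number from compound 1 to compound 3 (1.40 log units; beyond the scatter), since it also places a new group on an aromatic carbon of the same six-membered aromatic ring of carbon only; the step of a 4.6-fold higher number from compound 1 to compound 2 (0.66 log units; beyond the scatter) alters a different position and bears on it only loosely. A 4-methylpiperazin-1-yl group is, however, quite unlike trifluoromethyl, so the large step to compound 3 cannot be transferred with confidence.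

Compound 4 is therefore expected to give a higher number than compound 1, by the modest step of a 2.4-fold higher number from compound 1 to compound 4 (0.37 log units; beyond the scatter), with wide uncertainty. The estimate for compound 4 in this assay is 2000 nM, within a range from 500 nM to 10000 nM.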

Compound 4, half-maximal inhibitory concentration: 650 nM
Compound 4: the middle estimate sits 3.1-fold (0.49 log units) above what was measured, within the range that was stated.
By their numbers in this assay, from the lowest: compounds 4 and 1 (each within the scatter of the next); then compound 2; then compound 3.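

In this assay the new step is a 1.3-fold lower number from compound 1 to compound 4 (0.12 log units; within the scatter), so 4-methylpiperazin-1-yl in place of hydrogen on this aromatic carbon, para to a large group, leaves the number within the scatter of compound 1. Until now the only substitution on this six-membered aromatic ring of carbon only was a 25-fold higher number from compound 1 to compound 3 (1.40 log units; beyond the scatter); compound 4 shows that a new group on this ring does not in itself bring a higher number, even one with 7 heavy atoms and its own six-membered non-aromatic ring. Nothing available explains this outcome.

Going by these compounds, it remains open whether a smaller amine such as dimethylamino, or a morpholin-4-yl group, would behave like 4-methylpiperazin-1-yl at this place. On these data alone, it is also open whether trifluoromethyl at this same place would give a number near that of compound 1 or near that of compound 3.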